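A few compounds are considered here, and "the series" means these few. Any claim that something is new, unique, unknown or untested is made for them only; others in the source may bear on it.

Measured so far:
compound 1 `Cn1nc2c(=O)n(CC3(O)CCN(Cc4ccc(-c5cnco5)cc4Cl)CC3)cnc2c1-c1ccc(CN)cc1` gives 0.86 10^-6 cm/s in an ADME assay on Caco-2 cells (Homo sapiens) for permeability, in the apical to basolateral direction; a lower number here means that the compound crosses the layer more slowly, a higher number that the compound crosses the layer faster
compound 2 `Cn1nc2c(=O)n(CC3(O)CCN(Cc4ccc(-c5ccc(C(=O)O)o5)cc4Cl)CC3)cnc2c1-c1ccc(CN)cc1` gives 0.33 10^-6 cm/s in this assay

Of these two, compound 2 has the lower number at 0.33 10^-6 cm/s and compound 1 stands at 0.86 10^-6 cm/s as its nearest neighbour.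

Compound 3 `Cn1nc2c(=O)n(CC3(O)CCN(Cc4ccc(-c5ccco5)cc4Cl)CC3)cnc2c1-c1ccc(CN)cc1` differs from compound 2 by one change (hydrogen in place of carboxy on an aromatic carbon), which is hydrogen in place of carboxy on an aromatic carbon, or 5-carboxyfuran-2-yl to furan-2-yl.

Among the compounds with values here, one measured step bears on this: a 2.6-fold lower number from compound 1 to compound 2 (0.42 log units; beyond the scatter) is modest and beyond the scatter. Within the data shown here, it brought in the 5-carboxyfuran-2-yl group, but from 1,3-oxazol-5-yl, so the comparison is indirect and no measured compound carries furan-2-yl. On the strength of a 2.6-fold lower number from compound 1 to compound 2 (0.42 log units; beyond the scatter) a modest rise of similar size is expected in this assay on losing the carboxy. The expected step is a 3.0-fold higher number from compound 2 to compound 3 (0.48 log units; beyond the scatter) and it would bring the number close to that of compound 1.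

For compound 3 the expected value is 1 10^-6 cm/s with 0.45 10^-6 cm/s to 2.2 10^-6 cm/s as its estimated range.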

Compound 3, apparent permeability: 0.92 10^-6 cm/s
Compound 3: middle estimate off by 1.1-fold (0.04 log units), on the high side, and the stated range covers the measured number.
By their numbers in this assay, from the lowest: compound 2; then compounds 1 and 3 (each within the scatter of the next).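

Taking the carboxy off the 5-carboxyfuran-2-yl group gives the first direct reading at this carbon next to the ring oxygen: in this assay the change to hydrogen gives (a 2.8-fold higher number from compound 2 to compound 3 (0.45 log units; beyond the scatter)). The earlier step from compound 1 to compound 2 changed the ring and the carboxy together, whereas furan-2-yl and 1,3-oxazol-5-yl now compare directly (a 1.1-fold higher number from compound 1 to compound 3 (0.03 log units; within the scatter)). Among these three compounds, then, the low number of compound 2 goes with the carboxy and not with the furan ring, and no compound goes against this.

No measured property offers an explanation for either step. On these data alone, whether a primary amine, a methyl ester or a primary amide on this carbon would read like compound 2 or like compound 3 remains open.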